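A Methylpiperazine in Place of the Piperidinone Ring

The compounds below may be only part of what the source reports. "The series", "measured", "known", "first", "only" and "open" are said of these compounds alone.

Of the compounds shown here, three have so far been measured in an assay on HEK293 cells for inhibition of acid ceramidase (Homo sapiens), read by fluorescence, with stated times of 10 min and 3 h; on this read-out higher numbers stand for weaker inhibition and lower numbers for stronger inhibition. Compound 1 `CC(=O)N1CCc2oc(=O)n(C(=O)NCCCCc3ccccc3)c2C1` gives 293 nM in this assay. Compound 2 `CC(=O)N1CCC(c2ccc3c(c2)oc(=O)n3C(=O)NCCCCc2ccccc2)CC1` rests on a different shared core and gives 64 nM, and compound 3 `CN1CCC(c2ccc3c(c2)oc(=O)n3C(=O)NCCCCc2ccccc2)CC1=O` gives 105 nM. Compound 3 therefore stands second highest of the three numbers: the step of a 1.6-fold higher number from compound 2 to compound 3 (0.22 log units; within the scatter) is within the scatter, while the number for compound 1 sits above that of compound 3 by a gap beyond the scatter.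

Compound 4 `CN1CCN(c2ccc3c(c2)oc(=O)n3C(=O)NCCCCc2ccccc2)CC1` has not been measured. It differs from compound 3 in a single place: 4-methylpiperazin-1-yl in place of 1-methyl-2-oxopiperidin-4-yl on an aromatic carbon. Among the compounds with values here, only one measured step touches this place, namely a 1.6-fold higher number from compound 2 to compound 3 (0.22 log units; within the scatter), and it shows that exchanging one six-membered non-aromatic ring for another here shifted the number only within the scatter. Within the data shown here, no measured compound carries a ring with two hetero atoms at this place, so the direction of any shift cannot be read from the data.

Compound 4 is thus expected to give about 120 nM in this assay, with a likely range from 40 nM to 400 nM. This estimate means a 1.1-fold higher number from compound 3 to compound 4 (0.06 log units; within the scatter), a change expected to stay within the scatter.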

Compound 4, half-maximal inhibitory concentration: 116 nM
Compound 4: middle estimate off by 1.0-fold (0.01 log units), on the high side, within the range that was stated.
By their numbers in this assay, from the lowest: compounds 2, 3 and 4 (each within the scatter of the next); then compound 1.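

In this assay, 4-methylpiperazin-1-yl in place of 1-methyl-2-oxopiperidin-4-yl gives a 1.1-fold higher number from compound 3 to compound 4 (0.04 log units; within the scatter), and the same group in place of 1-acetylpiperidin-4-yl gives a 1.8-fold higher number from compound 2 to compound 4 (0.26 log units; within the scatter). Until now this place had held only a six-membered non-aromatic ring with 1 hetero atom and 1 double bond outside aromatic rings, whereas compound 4 carries a six-membered non-aromatic ring with 2 hetero atoms and no such double bond, and its number cannot be told apart from those of the other two compounds on this shared core. Among these three rings, then, neither the second hetero atom nor the loss of the double bond outside aromatic rings produces a step beyond the scatter, and no other measurement is available to help explain this result.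

Going by these compounds, all three compounds carry a six-membered non-aromatic ring at this place, so the effect of a carboxylic acid, an open chain ending in an amine, or a plain hydrogen there remains open. Also open, on these data alone, is how the number would respond if the methyl of the 4-methylpiperazin-1-yl group gave way to an acetyl group or a longer chain.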